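A few compounds are considered here, and "the series" means these few. Any claim that something is new, unique, unknown or untested is made for them only; others in the source may bear on it.

Of the compounds shown here, two that share one core have numbers so far in a functional assay on HepG2 cells (Homo sapiens) for cytotoxicity, read by MTT assay; a higher number here means a weaker inhibitor, a lower number a stronger inhibitor. Compound 1 `CCCCC(=O)Oc1cc(/C=C/C(=O)c2ccc(OC)c3c2OC(C)(C)C=C3)ccc1OC` gives 100 nM, and compound 2 `COc1ccc(/C=C/C(=O)c2ccc(OC)c3c2OC(C)(C)C=C3)cc1OC(=O)C1CC1` gives 220 nM, the higher of the two numbers and so the weaker inhibitor of this pair. Among the compounds with values here, the only measured step, a 2.2-fold higher number from compound 1 to compound 2 (0.34 log units; beyond the scatter), comes with cyclopropyl in place of butyl on a carbonyl carbon. It is modest, though beyond the usual scatter.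

Compound 3 `COc1ccc(/C=C/C(=O)Oc2cc(/C=C/C(=O)c3ccc(OC)c4c3OC(C)(C)C=C4)ccc2OC)cc1` has not yet been measured in this assay. It changes that same carbonyl carbon again: 2-(4-methoxyphenyl)ethenyl in place of cyclopropyl on a carbonyl carbon. Put simply, 2-(4-methoxyphenyl)ethenyl stands in place of cyclopropyl. Within the data shown here, no measured compound carries this aromatic group, so the single modest change, a 2.2-fold higher number from compound 1 to compound 2 (0.34 log units; beyond the scatter), is only a rough guide. It suggests that swapping this group need not move the number far, but it does not set a direction. The expected step, a 1.1-fold higher number from compound 2 to compound 3 (0.06 log units; within the scatter), therefore stays within the scatter, with a wide margin on either side. For compound 3 the estimated value is 250 nM, with an expected range from 70 nM to 900 nM.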

Compound 3, half-maximal inhibitory concentration: 430 nM
Beside the measured number, compound 3's estimate is 1.7-fold (0.24 log units) below it, within the range that was stated.
By their numbers in this assay, from the lowest: compound 1; then compounds 2 and 3 (each within the scatter of the next).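

On this carbonyl carbon, 2-(4-methoxyphenyl)ethenyl, with 10 heavy atoms and an aromatic ring, can stand in place of cyclopropyl, with 3 heavy atoms, without a change that can be told from the scatter in this assay: the data show a 2.0-fold higher number from compound 2 to compound 3 (0.29 log units; within the scatter). The comparison with butyl is clearer, with a 4.3-fold higher number from compound 1 to compound 3 (0.63 log units; beyond the scatter), so compound 1 remains the strongest inhibitor of the three, and both other groups on this carbon give numbers beyond the scatter from it. No measurement shown here accounts for this difference, and its cause remains unknown.

The compounds shown leave open whether butyl is close to the best chain length, since a shorter propyl or a longer hexyl chain on the same carbonyl carbon could give a lower or a higher number. They also leave open how a plain phenyl group, a carboxylic acid or an amine at this place would compare, and which part of 2-(4-methoxyphenyl)ethenyl, the methoxy group, the ring or the double bond, matters for the number.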